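A few compounds are considered here, and "the series" means these few. Any claim that something is new, unique, unknown or untested is made for them only; others in the source may bear on it.

Working notes on the series sharing the core of compound 1 (`Nc1nc(N)c2cc(CSC(=S)N3CCN(c4ccc(O)cc4)CC3)ccc2n1`), read in a functional assay on HCT-116 cells (Homo sapiens) for antiproliferative activity, read by MTT assay, with a stated time of 72 h; on this read-out lower numbers stand for stronger inhibition and higher numbers for weaker inhibition. Compound 1 gives 5980 nM, compound 2 (`Nc1nc(N)c2cc(CSC(=S)N3CCN(c4ccccc4Cl)CC3)ccc2n1`) gives 5490 nM, and compound 3 (`Nc1nc(N)c2cc(CSC(=S)N3CCN(c4ccccn4)CC3)ccc2n1`) gives 5960 nM. Compound 3 therefore stands within the scatter of both other compounds.

The next change leads to compound 4 (`Nc1nc(N)c2cc(CSC(=S)N3CCN(c4ncccn4)CC3)ccc2n1`), with pyrimidin-2-yl in place of pyridin-2-yl on an amine nitrogen in a ring. For the measured compounds named here, three measured steps bear on it, each exchanging the group at this same place: a 1.1-fold lower number from compound 1 to compound 2 (0.04 log units; within the scatter), a 1.0-fold lower number from compound 1 to compound 3 (0.00 log units; within the scatter) and a 1.1-fold higher number from compound 2 to compound 3 (0.04 log units; within the scatter). All three lie within the scatter, so the three groups tried so far are not separated in this assay. Going by the values given here, no measured compound carries pyrimidin-2-yl, which leaves this expectation resting on neighbouring groups alone. No step beyond the scatter is expected in either direction, and the expected change is a 1.0-fold lower number from compound 3 to compound 4 (0.01 log units; within the scatter). Compound 4 is estimated at 5800 nM, with an expected range of 3200 nM to 10000 nM.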

Compound 4, half-maximal inhibitory concentration: 5840 nM
Beside the measured number, compound 4's estimate is 1.0-fold (0.00 log units) below it, within the range that was stated.
By their numbers in this assay, from the lowest: compounds 2, 4, 3 and 1 (each within the scatter of the next).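

In this assay, the steps of a 1.0-fold lower number from compound 3 to compound 4 (0.01 log units; within the scatter), a 1.1-fold higher number from compound 2 to compound 4 (0.03 log units; within the scatter) and a 1.0-fold lower number from compound 1 to compound 4 (0.01 log units; within the scatter) show that pyrimidin-2-yl is not separated from any of the three earlier groups on the amine nitrogen in a ring. For the compounds shown here, the change from pyridin-2-yl is the first here to compare a ring with 2 hetero atoms and 2 hydrogen-bond acceptors against one with 1 of each, and that difference leaves the number within the scatter. Nothing available gives a reason for this flat result.

On these data alone, all four groups at this place are six-membered aromatic rings, so an open-chain group such as an ethyl or a longer alkyl chain, or a carboxylic acid on the ring, remains untested in these compounds. As far as these compounds go, whether any group on this nitrogen can move the number beyond the scatter also stays open.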